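Replacing a benzyloxy group in a hydrazone series

The compounds below may be only part of what the source reports. "The series", "measured", "known", "first", "only" and "open" are said of these compounds alone.

Measured so far:
compound 1 `Cc1nnc(SCC(=O)N/N=C2\C(=O)Nc3ccc([N+](=O)[O-])cc32)s1` – 93%
compound 2 `O=C(O)COc1ccc(/C=N/NC(=O)c2ccc(OCc3ccccc3)cc2)cc1` – "not determined" (no result reported)

Compound 1, in an assay on isolated protein for inhibition of Serotonin N-acetyltransferase (Ovis aries), read by spectrophotometry, tested at 100 uM (on this read-out lower numbers stand for less inhibition and higher numbers for more inhibition at the one concentration tested (going by the name of the read-out)), gives 93%. Compound 2 shares no core with compound 1. In this assay compound 2 has no number; the result for compound 2 is "not determined" (no result reported), so it stands nowhere on the scale shown. From compound 2 the step leads to compound 3 `Cc1ccc(C)n1-c1ccc(C(=O)N/N=C/c2ccc(OCC(=O)O)cc2)cc1`. The change is 2,5-dimethyl-1H-pyrrol-1-yl in place of benzyloxy on an aromatic carbon, set on an aromatic carbon of a six-membered aromatic ring of carbon only. Among the measured compounds shown here, because compound 2 has no value, the size and direction of this step in this assay cannot be set against the scatter; the only anchor is compound 1 with 93%, which is a different scaffold. Compound 3 is therefore expected to give about 40% in this assay, with a wide range from 10% to 80%.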

Compound 3, a percentage reported as inhibition, at one concentration (the size of the read-out at that concentration, not a potency): 92%
For compound 3 the middle estimate is 52 percentage points below the measured one; measured number above the stated range.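

In this assay compound 3 gives 92%, while the result for compound 2 is "not determined" (no result reported) and compound 1, with 93%, has a different core, so no step can be read. The compounds shown leave open what replacing benzyloxy with 2,5-dimethyl-1H-pyrrol-1-yl does to inhibition. No measured evidence bears on this result.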